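The source may hold more compounds than are shown below. What is called first, only, known or untested is meant among the compounds shown, and "the series" means these compounds.

Measured so far in a functional assay on MCF7 cells (Homo sapiens) for inhibition, read by sulforhodamine B assay, with a stated time of 48 h; a higher number here means a weaker inhibitor of growth, a lower number a stronger inhibitor of growth:

Compound 1 `CC(C)(C)NCc1c(C(=O)O)nn(-c2ccccc2)c1-c1ccc(Br)cc1`: 293000 nM
Compound 2 `CC(C)(C)NCc1c(C(=O)O)nn(-c2ccc(Cl)cc2)c1-c1ccc(Cl)cc1`: 246000 nM

Compound 2, at 246000 nM, sits within the usual scatter of compound 1, at 293000 nM, so these two numbers cannot be ranked. The next compound to consider is compound 3 `CC(C)(C)NCc1c(C(=O)O)nn(-c2ccc(Cl)cc2)c1-c1ccc(Br)cc1`, which keeps the rest of compound 2 and changes one group: 4-chlorophenyl becomes 4-bromophenyl. This is bromo in place of chloro on an aromatic carbon, para to a large group (bromo in place of chloro on an aromatic carbon).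

Going by the values given here, no pair differing only by this swap has been measured, so there is no direct step to go by. The nearest evidence is indirect. Compound 1 carries the bromo group and gives 293000 nM, while compound 2 carries chloro in that place and gives 246000 nM. That pair also differs elsewhere, yet its values show no gap beyond the scatter. No step beyond the scatter is therefore expected in this assay, in either direction. The estimate amounts to an expected step of a 1.1-fold higher number from compound 2 to compound 3 (0.02 log units; within the scatter). For compound 3 the estimated value is 260000 nM, with an expected range from 160000 nM to 420000 nM.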

Compound 3, concentration for 50% growth inhibition: 221000 nM
The estimate for compound 3 lay 1.2-fold (0.07 log units) above the measured number, within the range that was stated.
By their numbers in this assay, from the lowest: compounds 3, 2 and 1 (each within the scatter of the next).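

In this assay, the swap of 4-chlorophenyl to 4-bromophenyl can now be read directly, with nothing else in the molecule differing (a 1.1-fold lower number from compound 2 to compound 3 (0.05 log units; within the scatter)). Chloro and bromo on this aromatic carbon, para to a large group, therefore cannot be told apart in this growth assay, whereas the earlier comparison of compound 1 with compound 2 was blurred by a second difference. Compound 3 also gives the first clean reading of chloro in place of hydrogen on an aromatic carbon, and that step cannot be separated from the scatter either (a 1.3-fold lower number from compound 1 to compound 3 (0.12 log units; within the scatter)), while nothing shown explains why these changes leave the numbers so close.

The compounds shown cover only hydrogen, chloro and bromo at these places, so it remains open whether a methoxy group, a nitrile or an amine on the same aromatic carbon would give a step beyond the scatter. From the compounds shown here alone, it is also open how the numbers would respond if the carboxylic acid or the tert-butylamino group of the shared core were replaced, for example by an amide or a longer chain.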